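4-Fluorobenzyl to 4-bromobenzyl: compound 2 to compound 4

The source may hold more compounds than are shown below. What is called first, only, known or untested is meant among the compounds shown, and "the series" means these compounds.

Measured so far in a functional assay on BGC-823 cells (Homo sapiens) for inhibition, read by MTT assay, with a stated time of 72 h; on this read-out lower numbers stand for stronger inhibition and higher numbers for weaker inhibition:
- compound 1 `C[C@@H]1CCN(c2cc(-c3ccccc3)nc3ncnn23)C[C@@H]1N(C)c1ncnc2[nH]ccc12`: > 100000 nM (a limit of the assay)
- compound 2 `Cc1cc(N2CC[C@@H](C)[C@@H](N(C)c3ncnc4[nH]ccc34)C2)n2nc(SCc3ccc(F)cc3)nc2n1`: 44300 nM
- compound 3 `CCc1cc(N2CC[C@@H](C)[C@@H](N(C)c3ncnc4[nH]ccc34)C2)n2ncnc2n1`: 82200 nM

Going by the values given here, compound 2 and compound 3 hold the only two actual numbers, and these lie within the scatter of each other. The value of compound 1 is a limit, as the limit of > 100000 nM in this assay, at which 1 of the 3 values shown sits, records.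

Compound 4 `Cc1cc(N2CC[C@@H](C)[C@@H](N(C)c3ncnc4[nH]ccc34)C2)n2nc(SCc3ccc(Br)cc3)nc2n1` carries bromo in place of fluoro on an aromatic carbon of compound 2, para to a large group (bromo in place of fluoro on an aromatic carbon). Among the compounds with values here, the one measured step, an at least 1.2-fold lower number from compound 1 to compound 3 (0.08 log units; that floor lies within the scatter), is ethyl in place of phenyl on an aromatic carbon, a different change in a different place, and it gives no size for this one. Within the data shown here, with no measured step on this change, the expectation in this assay stays with compound 2 (44300 nM), and no shift beyond the scatter is expected. The estimated step is a 1.2-fold lower number from compound 2 to compound 4 (0.07 log units; within the scatter) (an expectation, without a firm direction). Compound 4 is expected at 38000 nM (estimated range 15000 nM to 95000 nM).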

Compound 4, half-maximal inhibitory concentration: 28000 nM
For compound 4 the middle estimate is 1.4-fold (0.13 log units) above the measured one; the range from low to high includes it.
By their numbers in this assay, from the lowest: compounds 4, 2 and 3 (each within the scatter of the next, the first and the last beyond it). At a limit, above all of these: compound 1.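

Bromo in place of fluoro, on an aromatic carbon para to a large group, gives a 1.6-fold lower number from compound 2 to compound 4 (0.20 log units; within the scatter) in this assay, the only measured step at this position. Compound 2 and compound 4 therefore cannot be ranked in this read-out, and this exchange of one halogen for the other shows no change beyond the scatter. Nothing measured here bears on what lies behind this step.

Going by these compounds, whether this place responds to anything other than a halogen stays open: an amine or a carboxylic acid at the same aromatic carbon could show whether the read-out moves beyond the scatter. Also open, on these data alone, is how a longer chain in place of the 4-bromobenzyl on the sulfanyl group would compare with compound 4 in this assay.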